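A few compounds are considered here, and "the series" means these few. Any claim that something is new, unique, unknown or untested is made for them only; others in the source may bear on it.

Measured in an in vitro ADME assay on microsomes from liver (Homo sapiens) for metabolic stability; on this read-out higher numbers stand for fast clearance and lower numbers for slow clearance:
- Compound 1 `Cc1cnc(NC(=O)c2cc(Oc3ccc(C(=O)N(C)C)cc3)c3cn(C)nc3c2)cn1`: 12.3 mL/min/kg
- Compound 2 `CCS(=O)(=O)c1ccc(Oc2cc(C(=O)Nc3cnc(C)cn3)cc3nn(C)cc23)cc1`: < 8 mL/min/kg (a limit)

Compound 2 reads < 8 mL/min/kg, and this is a limit of the assay, not a number. Among the two compounds measured, it is the only such case: the limit of < 8 mL/min/kg in this assay, at which 1 of the 2 values shown sits.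

Compound 3 `Cc1cnc(NC(=O)c2cc(Oc3ccc(S(=O)(=O)C4CC4)cc3)c3cn(C)nc3c2)cn1` keeps the shared core of compound 2 and differs in one place: cyclopropyl in place of ethyl on a sulfonyl sulfur. Put simply, this is cyclopropyl in place of ethyl on a sulfonyl sulfur, so ethylsulfonyl becomes cyclopropylsulfonyl.

Among the measured compounds shown here, only one measured step comes close to this change. It put ethylsulfonyl in place of dimethylcarbamoyl on an aromatic carbon: an at least 1.5-fold lower number from compound 1 to compound 2 (0.18 log units; that floor lies within the scatter). For the measured compounds named here, that step lies within the scatter, and no measured step alters the group on the sulfonyl sulfur. No change beyond the scatter is therefore expected in this assay, and compound 3 may well also be reported as a limit. The expected size of the change is a step that the limit leaves unreadable from compound 2 to compound 3. For compound 3 the estimated clearance is 6.5 mL/min/kg, with an expected range from 3.5 mL/min/kg to 12 mL/min/kg.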

Compound 3, clearance: < 8 mL/min/kg
Compound 3 was reported as a limit; the forecaster's own chance of this, stated with the estimate: 65%; the middle value lies beyond the limit too.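

In this assay, the sulfonyl position now tolerates a second group: with cyclopropyl in place of ethyl on the sulfonyl sulfur, which brings in a three-membered ring, compound 3 still reads as a limit of the assay and not as a number. The step from the earlier dimethylcarbamoyl compound reads an at least 1.5-fold lower number from compound 1 to compound 3 (0.18 log units; that floor lies within the scatter), so the two sulfonyl compounds give the same floor, and neither floor goes beyond the scatter. The step between the ethylsulfonyl and cyclopropylsulfonyl compounds cannot be read, and the result can show only that both sit at the same reporting limit, which now holds most of the series: the limit of < 8 mL/min/kg in this assay, at which 2 of the 3 values shown sit.

On these data alone, how far compound 2 and compound 3 lie under that limit remains unknown, so any real difference between ethyl and cyclopropyl stays hidden. Also open, as far as these compounds go, is whether a larger change on the sulfonyl sulfur, such as an amine or a longer chain, would lift the clearance to a value that can be read as a number.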